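Stretching the Ether Chain of Compound 3

The source may hold more compounds than are shown below. What is called first, only, known or untested is meant among the compounds shown, and "the series" means these compounds.

In a functional assay on brain (Rattus norvegicus, strain Wistar) for inhibition (a higher number here means a weaker inhibitor, a lower number a stronger inhibitor), compound 1 `Cc1[nH]c(=O)n(C2CCCCC2)c1-c1ccccc1` gives 47600 nM, compound 2 `CCCc1ccc(-c2c(C)[nH]c(=O)n2C2CCCCC2)cc1` gives 13900 nM, and compound 3 `Cc1[nH]c(=O)n(C2CCCCC2)c1-c1ccc(OC(C)C)cc1` gives 13000 nM. Compound 3 thus shares the low end of these numbers with compound 2. Compound 4 `Cc1[nH]c(=O)n(C2CCCCC2)c1-c1ccc(OCCC(C)C)cc1` carries one change: isopentyl in place of isopropyl on an oxygen on an aromatic ring. Replacing hydrogen on an aromatic carbon gave modest steps, a 3.4-fold lower number from compound 1 to compound 2 (0.53 log units; beyond the scatter) and a 3.7-fold lower number from compound 1 to compound 3 (0.56 log units; beyond the scatter), while exchanging propyl for isopropoxy gave a 1.1-fold lower number from compound 2 to compound 3 (0.03 log units; within the scatter), within the scatter. For the measured compounds named here, no measured step lengthens a chain on that oxygen, so this is only a loose guide. A small drop is expected, a 1.9-fold lower number from compound 3 to compound 4 (0.27 log units; within the scatter). For compound 4 the estimate is 7000 nM, with an expected range of 2500 nM to 16000 nM.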

Compound 4, half-maximal inhibitory concentration: 7200 nM
Beside the measured number, compound 4's estimate is 1.0-fold (0.01 log units) below it; the measured number falls inside the stated range.
By their numbers in this assay, from the lowest: compounds 4, 3 and 2 (each within the scatter of the next); then compound 1.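

Isopentyl in place of isopropyl on this oxygen gives a 1.8-fold lower number from compound 3 to compound 4 (0.26 log units; within the scatter) and so leaves the number unchanged within the scatter, as does the exchange of propyl for isopentyloxy, with a 1.9-fold lower number from compound 2 to compound 4 (0.29 log units; within the scatter) here. Measured against hydrogen on the aromatic carbon, isopentyloxy gives a 6.6-fold lower number from compound 1 to compound 4 (0.82 log units; beyond the scatter) and remains a modest gain, so this position accepts a longer branched chain without loss. No evidence here explains these numbers. On these data alone, whether an amine, a carboxylic acid or a still longer chain on that oxygen would shift the number beyond the scatter stays open.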